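The source may report more compounds than this note shows. Statements on the series, on what has been measured and on what is new or still open speak of the compounds shown alone.

compound 1 `CC1(C)[C@H]2CC[C@]1(C)N(Cc1cn(-c3cccc(F)c3)nn1)C(=O)C2` gives 80 nM
compound 2 `CC1(C)[C@H]2CC[C@]1(C)N(Cc1cn(-c3ccc(C#N)cc3)nn1)C(=O)C2` gives 50 nM
compound 3 `CC1(C)[C@H]2CC[C@]1(C)N(Cc1cn(-c3ccccc3C#N)nn1)C(=O)C2` gives 180 nM

All three values come from a functional assay on HepG2 cells (Homo sapiens) for inhibition, read by MTT assay, with a stated time of 24 h (on this read-out higher numbers stand for weaker inhibition and lower numbers for stronger inhibition), and compound 3 has the highest number of the set, so it is the weakest inhibitor of the three. The next compound, compound 4 `CC1(C)[C@H]2CC[C@]1(C)N(Cc1cn(-c3ccccc3Cl)nn1)C(=O)C2`, has not been measured yet. The change chloro in place of cyano on an aromatic carbon puts chloro in place of cyano on an aromatic carbon, so 2-cyanophenyl becomes 2-chlorophenyl.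

Within the data shown here, no measured pair shows this exact swap. The closest evidence comes from other changes to the same aryl group: the data show a 3.6-fold higher number from compound 2 to compound 3 (0.56 log units; beyond the scatter) and a 2.3-fold higher number from compound 1 to compound 3 (0.35 log units; beyond the scatter), and also a 1.6-fold lower number from compound 1 to compound 2 (0.20 log units; within the scatter) as the smallest step. None of these steps is large, and they give no direction for a swap of cyano to chloro. Compound 3 at 180 nM is therefore the natural starting point. The expected step is a 1.2-fold lower number from compound 3 to compound 4 (0.08 log units; within the scatter), so no change beyond the scatter is expected. In this assay compound 4 is estimated at 150 nM, with an expected range from 60 nM to 380 nM for its measured value.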

Compound 4, half-maximal inhibitory concentration: 60 nM
The estimate for compound 4 lay 2.5-fold (0.40 log units) above the measured number, within the range that was stated.
By their numbers in this assay, from the lowest: compounds 2, 4 and 1 (each within the scatter of the next); then compound 3.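

In this assay the change from cyano to chloro on this aromatic carbon brings a 3.0-fold lower number from compound 3 to compound 4 (0.48 log units; beyond the scatter) and shows that the group at this place on the phenyl ring matters, not only the fact that the place is occupied. The 2-chlorophenyl compound also sits level with the other two, with a 1.2-fold higher number from compound 2 to compound 4 (0.08 log units; within the scatter) and a 1.3-fold lower number from compound 1 to compound 4 (0.12 log units; within the scatter) both small enough to leave no order among them, so the higher number of compound 3 belongs to 2-cyanophenyl and does not extend to 2-chlorophenyl. No measurement shown gives a reason for the difference between cyano and chloro here.

Going by these compounds, whether a methoxy group, an amine or a carboxylic acid at this same place would behave like chloro or like cyano stays open. So does how chloro would fare elsewhere on the phenyl ring.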